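The source may report more compounds than this note shows. Statements on the series, on what has been measured and on what is new or still open speak of the compounds shown alone.

Working notes on the amide series in an assay on isolated protein for inhibition of phosphodiesterase 4A (Sus scrofa); a higher number here means a weaker inhibitor, a lower number a stronger inhibitor.

Compound 1 `COc1ccc(C(=O)Nc2c(F)cccc2Cl)cc1OC1CCCC1` gives 240 nM in this assay. Among the three measured compounds it holds the second highest number. The nearest value belongs to compound 3 `COc1ccc(C(=O)Nc2c(F)c(F)nc(F)c2Cl)cc1OC1CCCC1`, which gives 100 nM in this assay, a lower number and a gap beyond the scatter. The furthest value belongs to compound 2 `COc1ccc(C(=O)Nc2ccccc2Cl)cc1OC`, which gives 650 nM in this assay, a higher number and again a gap beyond the scatter. No pair among these three differs in a single place, so no step within the series is available as a guide.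

Compound 4 `COc1ccc(C(=O)NC2(C)C=C(C)ON2)cc1OC1CCCC1` is not yet measured. Compared with compound 1 the change is a group of 7 heavy atoms (5 carbon, 1 nitrogen, 1 oxygen; one five-membered non-aromatic ring with 2 hetero atoms) in place of a group of 8 heavy atoms (6 carbon, 1 fluorine, 1 chlorine; one six-membered aromatic ring of carbon only), on an amide-type nitrogen. The entering group is a five-membered non-aromatic ring with two hetero atoms carrying one hydrogen-bond donor and two acceptors, replacing an aromatic six-membered carbon ring with no donors or acceptors, on the amide-type nitrogen.

Nothing measured here covers such a change, so the expectation is loose. The number for compound 4 is expected to move upward, to a weaker inhibitor, by a step of a 6.3-fold higher number from compound 1 to compound 4 (0.80 log units; beyond the scatter), which is beyond the scatter. Compound 4 is therefore estimated at 1500 nM in this assay, within a range from 300 nM to 8000 nM.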

Compound 4, half-maximal inhibitory concentration: 450 nM
Estimate against measurement, compound 4: 3.3-fold (0.52 log units) above; low and high end bracket the measured number.
By their numbers in this assay, from the lowest: compound 3; then compounds 1, 4 and 2 (each within the scatter of the next, the first and the last beyond it).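

In this assay the step of a 1.9-fold higher number from compound 1 to compound 4 (0.27 log units; within the scatter) shows that the amide-type nitrogen of the shared core accepts a very different group with no change beyond the scatter. At this place, the 2-chloro-6-fluorophenyl can give way to a five-membered non-aromatic ring with 2 hetero atoms, so neither an aromatic carbon ring nor the fluorine and chlorine are needed to stay at this level, at least in this one pair, and the hydrogen-bond donor and acceptors that enter with the new ring leave the number within the scatter as well. No measurement among the data presented bears on why the two groups sit at this level, and none can be called on for this result.

Among the compounds shown here, the single pair does not separate the parts of the entering group, so it remains open whether a plain cyclopentyl or an unsubstituted phenyl on the same amide-type nitrogen would stay at this level too. Also open, on these data alone, is whether a group with a basic amine or a carboxylic acid on the ring would be accepted here, and whether the same exchange would read alike on the core of compound 2.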